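The source may report more compounds than this note shows. Statements on the series, on what has been measured and on what is new or still open speak of the compounds shown alone.

Working notes on the series. Going by the values given here, compound 1 `Nc1n[nH]c2cccc(-c3cccc(NC(=O)Nc4cccc(Cl)c4)c3)c12` gives 1720 nM in a functional assay on A549 cells (Homo sapiens) for inhibition, read by MTT assay, with a stated time of 48 h (on this read-out lower numbers stand for stronger inhibition and higher numbers for weaker inhibition), the lowest of the three numbers so far, although compound 3 `Cc1ccc(NC(=O)Nc2cccc(-c3cccc4[nH]nc(N)c34)c2)cc1Cl` at 1750 nM and compound 2 `COc1cccc(NC(=O)Nc2cccc(-c3cccc4[nH]nc(N)c34)c2)c1` at 2490 nM both sit within the scatter of it. Compound 4 `Cc1ccc(NC(=O)Nc2cccc(-c3cccc4[nH]nc(N)c34)c2)cc1` has not been measured; it differs from compound 1 by 4-methylphenyl in place of 3-chlorophenyl on an amide-type nitrogen. Among the compounds with values here, two measured steps bear on this change: a 1.4-fold higher number from compound 1 to compound 2 (0.16 log units; within the scatter) and a 1.0-fold higher number from compound 1 to compound 3 (0.01 log units; within the scatter), both within the scatter. Within the data shown here, compound 4 also stands to compound 3 as removal of the chloro, for which no step is measured. Nothing here points to a movement beyond the scatter, so compound 4 is expected at 2000 nM (range 1000 nM to 4000 nM), which amounts to an expected 1.2-fold higher number from compound 1 to compound 4 (0.07 log units; within the scatter).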

Compound 4, half-maximal inhibitory concentration: 1660 nM
Beside the measured number, compound 4's estimate is 1.2-fold (0.08 log units) above it, within the range that was stated.
By their numbers in this assay, from the lowest: compounds 4, 1, 3 and 2 (each within the scatter of the next).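

Moving the substituent pattern on the aryl group at the amide-type nitrogen changes little in this assay: 4-methylphenyl in place of 3-chlorophenyl (a 1.0-fold lower number from compound 1 to compound 4 (0.02 log units; within the scatter)) and in place of 3-methoxyphenyl (a 1.5-fold lower number from compound 2 to compound 4 (0.18 log units; within the scatter)) both stay within the scatter. Removal of the chloro, not read before, also stays within it (a 1.1-fold lower number from compound 3 to compound 4 (0.02 log units; within the scatter)), so the chloro is not needed for this level of inhibition. Nothing at hand explains this lack of movement.

On these data alone, whether an amine, a carboxylic acid or a longer chain on this aryl group would move the number beyond the scatter remains open.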